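The source may report more compounds than this note shows. Statements on the series, on what has been measured and on what is new or still open speak of the compounds shown alone.

Compound 2 `O=C1C=CC(=O)N1c1cc(C(F)(F)F)cc(C(F)(F)F)c1` carries a group of 7 heavy atoms (4 carbon, 1 nitrogen, 2 oxygen; one five-membered non-aromatic ring with 1 hetero atom) on an aromatic carbon of the shared core. In an ADME assay for pharmacokinetics, read by HPLC, in phosphate buffer, with a stated time of 72 h, at pH 7.4, tested at 250 uM (a lower number here means that the compound disappears faster, a higher number that the compound lasts longer), compound 2 gives < 0.017 h, which is a limit of the assay and not a number. Compound 1 `C=CS(=O)(=O)c1cc(C(F)(F)F)cc(C(F)(F)F)c1` differs from it only at that position. In this assay compound 1 gives < 0.017 h, again a limit. The step that the two limits leave unreadable from compound 1 to compound 2 is therefore unreadable, and the limit of < 0.017 h in this assay, at which 2 of the 2 values shown sit, is all the evidence the two measured compounds offer. Compound 3 `FC(F)(F)c1cc(C2CO2)cc(C(F)(F)F)c1` is the next member; it differs from compound 2 by a group of 3 heavy atoms (2 carbon, 1 oxygen; one three-membered non-aromatic ring with 1 hetero atom) in place of a group of 7 heavy atoms (4 carbon, 1 nitrogen, 2 oxygen; one five-membered non-aromatic ring with 1 hetero atom), on an aromatic carbon. For the measured compounds named here, no measured step bears on this change, and because compound 2 stands at < 0.017 h, any readable value for compound 3 would amount to a longer half-life. Compound 3 is expected to give 30 h, between 3 h and 300 h. That estimate implies a step of an at least 1700-fold higher number from compound 2 to compound 3 (3.24 log units; beyond the scatter), expected rather than measured.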

Compound 3, half-life: 6 h
For compound 3 the middle estimate is 5.0-fold (0.70 log units) above the measured one; the range from low to high includes it.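

For the compounds shown here, compound 3 is the first compound in this assay with a half-life that reads as a number and not as a limit, so the group at this position on the shared core now visibly matters. The change from the five-membered ring to oxiran-2-yl is an at least 350-fold higher number from compound 2 to compound 3 (2.54 log units; beyond the scatter), and the change from vinylsulfonyl to oxiran-2-yl is an at least 350-fold higher number from compound 1 to compound 3 (2.54 log units; beyond the scatter); both steps lie beyond the scatter, and each is open-ended. The step between compound 1 and compound 2 still cannot be read, and the evidence for those two is unchanged: the limit of < 0.017 h in this assay, at which 2 of the 3 values shown sit.

Going by these compounds, whether another group at this position, such as an amine, a carboxylic acid or a longer chain, would last as long as oxiran-2-yl stays open. The compounds shown also do not rank vinylsulfonyl against the five-membered ring.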